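Swapping fluoro for trifluoromethyl on a weak antiproliferative series

The source may hold more compounds than are shown below. What is called first, only, known or untested is meant among the compounds shown, and "the series" means these compounds.

Compound 1 `O=C(O)CC(NS(=O)(=O)c1ccc(C(F)(F)F)cc1)c1ccccc1`: 54700 nM
Compound 2 `CC(C)(C)c1ccc(C(CC(=O)O)NS(=O)(=O)c2ccccc2)cc1`: > 100000 nM
Compound 3 `CC(C)(C)c1ccc(C(CC(=O)O)NS(=O)(=O)c2ccc(F)cc2)cc1`: 68900 nM

All three values come from a functional assay on MDA-MB-436 cells (Homo sapiens) for antiproliferative activity, read by MTT assay, with a stated time of 24 h; a higher number here means a weaker inhibitor, a lower number a stronger inhibitor. Compound 2 sits at a limit of the assay, > 100000 nM, and this is not a true number. Compound 3 at 68900 nM and compound 1 at 54700 nM lie within the scatter of each other, so neither can be ranked ahead.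

The next compound, compound 4 `CC(C)(C)c1ccc(C(CC(=O)O)NS(=O)(=O)c2ccc(C(F)(F)F)cc2)cc1`, keeps the frame of compound 3 but puts trifluoromethyl in place of fluoro on an aromatic carbon. Among the measured compounds shown here, only one measured step bears on this place, an at least 1.4-fold lower number from compound 2 to compound 3 (0.16 log units; that floor lies within the scatter), and it is a floor rather than a full size. With that small step, and with compound 1, which also carries trifluoromethyl, at 54700 nM, no shift beyond the scatter is expected in this assay. The expected step is a 1.4-fold lower number from compound 3 to compound 4 (0.14 log units; within the scatter). For compound 4 the estimated value is 50000 nM, with an expected range of 18000 nM to 100000 nM.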

Compound 4, half-maximal inhibitory concentration: 60100 nM
Beside the measured number, compound 4's estimate is 1.2-fold (0.08 log units) below it; the measured number falls inside the stated range.
By their numbers in this assay, from the lowest: compounds 1, 4 and 3 (each within the scatter of the next). At a limit, above all of these: compound 2.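

In this assay, the change on the aromatic carbon para to a large group shows up as a 1.1-fold lower number from compound 3 to compound 4 (0.06 log units; within the scatter), so at this position trifluoromethyl and fluoro cannot be told apart. With trifluoromethyl held in place, adding tert-butyl gives no readable change either: a 1.1-fold higher number from compound 1 to compound 4 (0.04 log units; within the scatter). Against hydrogen at this position the change reads as an at least 1.6-fold lower number from compound 2 to compound 4 (0.22 log units; that floor lies within the scatter), which is only a floor, and compound 2 stands at a limit, not a true number: the limit of > 100000 nM in this assay, at which 1 of the 4 values shown sits.

The compounds shown leave open whether any group at this position, such as an amine or a methoxy group, could move the number beyond the scatter. They also leave open whether a change elsewhere, such as an amide in place of the carboxylic acid, would do so.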